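This account rests on a few compounds, and the source may have more. Where it says the series, first, only, none or still open, it means among the compounds named here.

Measured so far in an assay on isolated protein for agonist activity at Free fatty acid receptor 1 (Homo sapiens); a higher number here means that more compound is needed for the effect, a lower number that less compound is needed:
compound 1, `CC#CC(CC(=O)O)c1ccc(OCc2ccn3cc(-c4ccc(C(C)C)cc4)nc3c2)cc1`, gives 615 nM
compound 2, `CC#CC(CC(=O)O)c1ccc(OCc2ccn3cc(-c4ccc(CC)cc4)nc3c2)cc1`, gives 671 nM
compound 3, `CC#CC(CC(=O)O)c1ccc(OCc2ccn3cc(-c4cc(F)ccc4F)nc3c2)cc1`, gives 639 nM

Compound 3 stands second highest of these three numbers. Its nearest neighbour is compound 1, separated by a 1.0-fold higher number from compound 1 to compound 3 (0.02 log units; within the scatter), and its furthest is compound 2, separated by a 1.1-fold lower number from compound 2 to compound 3 (0.02 log units; within the scatter); both of these gaps fall within the scatter, so the three compounds cannot be told apart on the numbers at hand.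

Compound 4, `CC#CC(CC(=O)O)c1ccc(OCc2ccn3cc(-c4ccc(F)cc4F)nc3c2)cc1`, is not yet measured. It differs from compound 3 only in the aryl group attached to the shared core: 2,4-difluorophenyl in place of 2,5-difluorophenyl on an aromatic carbon.

Two of the measured steps bear on this change, since each replaces the aryl group at the same position: a 1.0-fold higher number from compound 1 to compound 3 (0.02 log units; within the scatter) and a 1.1-fold lower number from compound 2 to compound 3 (0.02 log units; within the scatter). Neither moved the number beyond the scatter, and the remaining step, a 1.1-fold higher number from compound 1 to compound 2 (0.04 log units; within the scatter), was likewise silent. No measured step moves a fluorine from one ring position to another, so the change in compound 4 has no direct precedent, but the aryl swaps seen so far give no reason to expect movement.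

Compound 4 is therefore expected to show no step beyond the scatter, a 1.0-fold higher number from compound 3 to compound 4 (0.00 log units; within the scatter). The estimate for compound 4 in this assay is 640 nM, with a range from 320 nM to 1300 nM.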

Compound 4, half-maximal effective concentration: 792 nM
For compound 4 the middle estimate is 1.2-fold (0.09 log units) below the measured one; the measured number falls inside the stated range.
By their numbers in this assay, from the lowest: compounds 1, 3, 2 and 4 (each within the scatter of the next).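

In this assay, the exchange of 2,5-difluorophenyl for 2,4-difluorophenyl gives a 1.2-fold higher number from compound 3 to compound 4 (0.09 log units; within the scatter): this is the first step shown in which the entering and leaving groups hold the same atoms joined differently, and it stays within the scatter. The exchanges of 4-ethylphenyl and 4-isopropylphenyl for 2,4-difluorophenyl, at the same aromatic carbon of the five-membered ring, give a 1.2-fold higher number from compound 2 to compound 4 (0.07 log units; within the scatter) and a 1.3-fold higher number from compound 1 to compound 4 (0.11 log units; within the scatter), so all four aryl groups now shown remain indistinguishable on these numbers, whether they carry fluorine or an alkyl chain. No supporting measurement accounts for this flat picture.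

On these data alone, all four compounds carry a substituted phenyl group at this position, so it remains open whether any other group there, such as a morpholine, or a phenyl bearing an amine or a nitrile, would move the number beyond the scatter. As far as these compounds go, it also remains open whether the unsubstituted phenyl group or a monofluorophenyl group would stay level with these four.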